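Trifluoromethoxy in place of isopropyl on the shared core

This account rests on a few compounds, and the source may have more. Where it says the series, first, only, none or still open, it means among the compounds named here.

Among the measured compounds shown here, in an ADME assay on L6 cells (Rattus norvegicus) for cytotoxicity, read by resazurin assay, with a stated time of 72 h (a higher number here means a weaker inhibitor, a lower number a stronger inhibitor), compound 1 `Cc1occc1C(=O)NC(=O)c1ccccc1O` gives 16 ug/mL and compound 2 `CC(C)c1ccc(C(=O)NC(=O)c2ccccc2O)cc1` gives 19 ug/mL as the only numbers so far. These two values lie within the scatter of each other, so compound 2 stands level with compound 1 and no ranking can be drawn. For the measured compounds named here, no measured pair differs in one place only, which leaves no direct measure of a single change.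

Compound 3 `O=C(NC(=O)c1ccccc1O)c1ccc(OC(F)(F)F)cc1` has no number yet. Relative to compound 2 it carries trifluoromethoxy in place of isopropyl on an aromatic carbon, para to a large group (trifluoromethoxy in place of isopropyl on an aromatic carbon). No step beyond the scatter is expected for this change in this assay on present evidence. That expectation rests only on compound 2 at 19 ug/mL and compound 1 at 16 ug/mL sitting close together. The estimated step (a 1.3-fold lower number from compound 2 to compound 3 (0.10 log units; within the scatter)) stays within the scatter. For compound 3 the expected value is 15 ug/mL with an estimated range from 6 ug/mL to 36 ug/mL in this measurement.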

Compound 3, half-maximal inhibitory concentration: 84 ug/mL
Compound 3: the middle estimate sits 5.6-fold (0.75 log units) below what was measured; the measured number lies above the stated range.
By their numbers in this assay, from the lowest: compounds 1 and 2 (each within the scatter of the next); then compound 3.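

In this assay the exchange of isopropyl for trifluoromethoxy on this aromatic carbon, para to a large group, gives a 4.4-fold higher number from compound 2 to compound 3 (0.65 log units; beyond the scatter) and so provides the first measured size for a change in one place in the series. The earlier compounds shown here, which differ in more than one place, could not show that this position affects the read-out; the pair of compound 2 and compound 3 shows that it does, with trifluoromethoxy giving the higher number and so the weaker inhibition of the two. Nothing at hand bears on the cause of this step.

Going by these compounds, the finding rests on a single pair on the shared core, so it remains open whether the step reflects something particular to trifluoromethoxy or would appear with other replacements for isopropyl, and whether it would carry over to other positions. A carboxylic acid, an amine or a longer chain on the same aromatic carbon would show how far the number in this assay follows the group at this place.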